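The source may hold more compounds than are shown below. What is called first, only, known or untested is meant among the compounds shown, and "the series" means these compounds.

Three hydrazones built on one shared core were examined in an ADME assay on J774 cells (Mus musculus) for cytotoxicity, read by MTT assay, with a stated time of 48 h, tested at 50 ug/mL; on this read-out higher numbers stand for a weaker effect at the one concentration tested and lower numbers for a stronger effect. Compound 1 `O=C(N/N=C/c1ccccc1Cl)c1cnccn1` gave 70%, while compound 3 `O=C(N/N=C/c1ccccc1F)c1cnccn1` gave 100%. The two differ in a single place: fluoro in place of chloro on an aromatic carbon. That change produced a number 30 percentage points higher from compound 1 to compound 3 (beyond the scatter). Compound 2 `O=C(N/N=C/c1ccc(Cl)cc1)c1cnccn1` has the same atoms as compound 1 joined differently, and the difference between the two cores is not broken down here. In this assay compound 2 gave 83%, the second highest of the three numbers, with compound 1 lower and compound 3 higher, both gaps beyond the scatter.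

Compound 4 `O=C(N/N=C/c1ccc(F)cc1)c1cnccn1` has not yet been measured in this assay. It differs from compound 2 by fluoro in place of chloro on an aromatic carbon. Among the measured compounds shown here, this is the same kind of change as the one from compound 1 to compound 3, but not the same: there the entering fluoro stands ortho to a large group, here it stands para to a large group. For the measured compounds named here, only that one earlier example is available to guide an expectation, and compound 2 already starts from a high number. Because the earlier change brought a number 30 percentage points higher from compound 1 to compound 3 (beyond the scatter), the estimated step here is expected to be a number 14 percentage points higher from compound 2 to compound 4 (beyond the scatter), in the same direction though somewhat smaller. The expected value for compound 4 in this assay is 97%. The expected range for compound 4 runs from 85% to 108%.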

Compound 4, a percentage reported as activity, at one concentration (the size of the read-out at that concentration, not a potency): 78%
Beside the measured number, compound 4's estimate is 19 percentage points above it, outside the stated range (below it).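

In this assay, the change of fluoro in place of chloro on an aromatic carbon did not carry over from one core to the other with the same outcome: the same change on two cores in this assay, a number 30 percentage points higher (beyond the scatter) from compound 1 to compound 3 and a number 5 percentage points lower (within the scatter) from compound 2 to compound 4, 35 percentage points apart, beyond the scatter of two such steps. On the core of compound 2, where the entering fluoro stands para to a large group, the swap gave a number 5 percentage points lower from compound 2 to compound 4 (within the scatter), so this pair shows no separation between the two halogens, whereas the pair on the core of compound 1 does show one, and the step measured on one core therefore cannot serve as a reliable guide to the step on the other in this series. Among the compounds shown here, what this does not show is why the two steps part, since there is only one pair on each core, and it cannot settle whether the difference follows from where the halogen stands on the ring or whether either outcome would recur on a further core.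

The compounds shown carry only chloro and fluoro on the aromatic ring, so it remains open how a methoxy group, an amine or a carboxylic acid at the same places would read in this assay. From the compounds shown here alone, it also remains open whether such groups would show the same dependence on the core as the two halogens do here.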